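A Pyrrole in Place of a Methylphenyl Group

This account rests on a few compounds, and the source may have more. Where it says the series, first, only, none or still open, it means among the compounds named here.

Three members of this series have been measured in a functional assay on SMMC-7721 cells (Homo sapiens) for antiproliferative activity, read by MTT assay, with a stated time of 72 h; a lower number here means a stronger inhibitor, a higher number a weaker inhibitor. Within the data shown here, compound 2 `C#CCSc1nc(Sc2nccs2)c(C#N)c(-c2ccc(C)cc2)n1` is the only one that gives a number, 2450 nM in this assay. Compound 1 `C#CCSc1nc(Sc2nc3ccccc3s2)c(C#N)c(-c2cc(OC)c(OC)c(OC)c2)n1` reaches only a limit of the assay, > 20000 nM. Compound 3 `C#CCSc1nc(Sc2nc(C)c(C)s2)c(C#N)c(-c2cc(OC)c(OC)c(OC)c2)n1` likewise sits at a limit, > 20000 nM. Among the measured compounds shown here, the one step between measured compounds that differ in a single place, a step that the two limits leave unreadable from compound 1 to compound 3, cannot be read because both of its ends rest on (the limit of > 20000 nM in this assay, at which 2 of the 3 values shown sit). Compound 4 `C#CCSc1nc(Sc2nccs2)c(C#N)c(-c2ccc[nH]2)n1` differs from compound 2 by 1H-pyrrol-2-yl in place of 4-methylphenyl on an aromatic carbon. For the measured compounds named here, no measured step touches this position, and the two limits offer no size for comparison, so nothing measured bears on the change. The expected step of a 1.6-fold higher number from compound 2 to compound 4 (0.21 log units; within the scatter) is therefore small and lies within the usual scatter, although the band around it must be kept wide. For compound 4 the estimate in this assay is 4000 nM, between 1200 nM and 15000 nM.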

Compound 4, half-maximal inhibitory concentration: > 20000 nM
Compound 4: only a limit was reported; the forecaster's own chance of this, stated with the estimate: 30%; middle value at least 5.0-fold (0.69 log units) from the limit.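

In this assay, the aromatic carbon ortho to a cyano group proves sensitive to what it carries: 1H-pyrrol-2-yl in place of 4-methylphenyl gives an at least 8.1-fold higher number from compound 2 to compound 4 (0.91 log units; beyond the scatter). Among these compounds, this is the first readable step, and it shows that, with the (1,3-thiazol-2-yl)sulfanyl group held fixed, the change at this position is enough on its own to carry the compound to the limit of the assay. The true size of the step stays unknown, because the value of compound 4 is a limit and not a number: the limit of > 20000 nM in this assay, at which 3 of the 4 values shown sit.

The compounds shown do not tell whether the loss follows from the smaller ring or from its ring nitrogen hydrogen, which a plain phenyl or a 1-methyl-1H-pyrrol-2-yl group could separate. Going by these compounds, it also remains open whether an amine at this position would keep activity.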